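The source may hold more compounds than are shown below. What is called first, only, known or untested is meant among the compounds shown, and "the series" means these compounds.

Compound 2 `O=C(C[C@H](NC(=O)c1ccc(C#Cc2ccccc2)cc1)C(=O)NO)NCCCO` gives 82000 nM in a physicochemical assay for solubility; on this read-out higher numbers stand for higher solubility and lower numbers for lower solubility. Within the data shown here, it is one of only two compounds measured; the other, compound 1 `NC(=O)C[C@H](NC(=O)c1ccc(C#Cc2ccccc2)cc1)C(=O)NO`, gives 61000 nM in this assay, and the single recorded step is a 1.3-fold higher number from compound 1 to compound 2 (0.13 log units; within the scatter), so the two numbers lie within the scatter of each other and no order between them can be read. Compound 3 `NC[C@H](NC(=O)c1ccc(C#Cc2ccccc2)cc1)C(=O)NO` has not yet been measured in this assay. It differs from compound 2 by amino in place of (3-hydroxypropyl)carbamoyl on a saturated chain carbon, two bonds along the chain from an amide-type nitrogen and a carbonyl carbon. Among the measured compounds shown here, no measured step bears on this change: the one step recorded concerned the 3-hydroxypropyl on an amide-type nitrogen, stayed within the scatter, and shows only the scale of the numbers. The step expected for compound 3 is accordingly a 1.2-fold higher number from compound 2 to compound 3 (0.09 log units; within the scatter), not beyond the scatter. Compound 3 is estimated at 100000 nM in this assay, with a range from 30000 nM to 330000 nM.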

Compound 3, solubility: 13000 nM
For compound 3 the middle estimate is 7.7-fold (0.89 log units) above the measured one; the measured number lies below the stated range.
By their numbers in this assay, from the lowest: compound 3; then compounds 1 and 2 (each within the scatter of the next).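

In this assay this position, on a saturated chain carbon, proves sensitive to the change: there is a 6.3-fold lower number from compound 2 to compound 3 (0.80 log units; beyond the scatter) when amino replaces (3-hydroxypropyl)carbamoyl, and a 4.7-fold lower number from compound 1 to compound 3 (0.67 log units; beyond the scatter) when amino replaces carbamoyl, both beyond the scatter. Among these compounds, the earlier step altered only the amide-type nitrogen of this group and stayed within the scatter, whereas replacing the whole group with amino moves the number clearly for the first time. Nothing available accounts for the size of these steps.

The compounds shown leave open whether the lower number goes with the amino group itself or with the loss of the carbamoyl, and a hydroxyl or a carboxylic acid at this place would help separate the two. Going by these compounds, it also remains open whether a 3-hydroxypropyl on the amino nitrogen of compound 3 would change the number.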